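Cytotoxicity series: exchange at the five-membered ring of compound 3

The source may hold more compounds than are shown below. What is called first, only, known or untested is meant among the compounds shown, and "the series" means these compounds.

Measured so far, in a functional assay on MCF7 cells (Homo sapiens) for cytotoxicity, read by MTT assay, with a stated time of 72 h; a higher number here means a weaker inhibitor, a lower number a stronger inhibitor:
compound 1 `NS(=O)(=O)c1cc(-c2nnc(CN3CCN(c4ccc(Cl)cc4)CC3)o2)c(Cl)cc1SCc1ccccc1`, 280000 nM
compound 2 `NS(=O)(=O)c1cc(-c2nnc(CN3CCN(c4ccc(F)cc4)CC3)o2)c(Cl)cc1SCc1ccccc1`, 240000 nM
compound 3 `NC(=O)c1cn(Cc2nnc(-c3cc(S(N)(=O)=O)c(SCc4ccccc4)cc3Cl)o2)nn1`, 78000 nM

Compound 3 stands lowest of the three numbers in this assay, with steps to compound 2 and compound 1 that lie beyond the scatter, so it is the strongest inhibitor among the measured compounds. Going by the values given here, the only single-point step measured is a 1.2-fold lower number from compound 1 to compound 2 (0.07 log units; within the scatter), and it does not touch the part of the molecule changed here.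

Compound 4 `NS(=O)(=O)c1cc(-c2nnc(/C=C/c3ccc(Cl)cc3)o2)c(Cl)cc1SCc1ccccc1` differs from compound 3 in one place: 2-(4-chlorophenyl)ethenyl in place of (4-carbamoyl-1H-1,2,3-triazol-1-yl)methyl on an aromatic carbon. Among the compounds with values here, no measured pair shows this exchange or anything like it, so the step from compound 3 to compound 4 in this assay cannot be anchored to a measured step. Compound 1 and compound 2 show that a different large group at the same place gives numbers higher than compound 3; on that basis the number for compound 4 is expected to rise, with a 1.9-fold higher number from compound 3 to compound 4 (0.28 log units; within the scatter) as the estimated step, though it is a loose expectation. Compound 4 is therefore estimated at 150000 nM, in a range from 50000 nM to 450000 nM.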

Compound 4, half-maximal inhibitory concentration: 11000 nM
Estimate against measurement, compound 4: 14-fold (1.13 log units) above; the whole stated range lies above it.
By their numbers in this assay, from the lowest: compound 4; then compound 3; then compounds 2 and 1 (each within the scatter of the next).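

In this assay, the place on the five-membered aromatic ring with 2 nitrogen and 1 oxygen proves sensitive to which large group it carries: 2-(4-chlorophenyl)ethenyl in place of (4-carbamoyl-1H-1,2,3-triazol-1-yl)methyl gives a 7.1-fold lower number from compound 3 to compound 4 (0.85 log units; beyond the scatter). Both groups hold the same count of heavy atoms, so that count does not separate them; they differ in ring, in the chlorine and in hydrogen-bond donors and acceptors, and this one pair cannot show which of these carries the step. Nothing at hand explains the drop in the number.

Open, from the compounds shown here alone, is how 2-phenylethenyl, without the chlorine, or 2-(4-chlorophenyl)ethyl, without the double bond, would stand at this place. Also open, going by these compounds, is where a carboxylic acid in place of the carbamoyl would fall.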